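A few compounds are considered here, and "the series" means these few. Any claim that something is new, unique, unknown or untested is made for them only; others in the source may bear on it.

Measured so far:
compound 1 `N#Cc1ccc2c(Oc3ccccc3OCCn3ccc(=O)[nH]c3=O)cc(F)cc2c1`: > 100000 nM
compound 2 `N#Cc1ccc2c(Oc3ccc(Cl)cc3OCCn3ccc(=O)[nH]c3=O)cc(F)cc2c1`: 18000 nM
compound 3 `N#C/C=C/c1cc(Cl)cc(Oc2ccccc2OCCn2ccc(=O)[nH]c2=O)c1`: 18000 nM

In an ADME assay on MT2 cells (Homo sapiens) for cytotoxicity, read by MTT assay (a lower number here means that less compound is tolerated, a higher number that more compound is tolerated), compound 1 gives > 100000 nM, which is a limit of the assay and not a number (the limit of > 100000 nM in this assay, at which 1 of the 3 values shown sits). Compound 2 differs from compound 1 by chloro in place of hydrogen on an aromatic carbon. In this assay compound 2 sits at 18000 nM; the step is an at least 5.5-fold lower number from compound 1 to compound 2 (0.74 log units; beyond the scatter). Compound 3 gives 18000 nM, level with compound 2 at the digits given. How the core of compound 3 differs from that of compound 1 is not broken down here.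

Compound 4 `N#C/C=C/c1cc(Cl)cc(Oc2ccc(Cl)cc2OCCn2ccc(=O)[nH]c2=O)c1` is not yet measured in this assay. It differs from compound 3 by chloro in place of hydrogen on an aromatic carbon, the same change made from compound 1 to compound 2. Resting on an at least 5.5-fold lower number from compound 1 to compound 2 (0.74 log units; beyond the scatter), a step of similar direction is expected: a 3.6-fold lower number from compound 3 to compound 4 (0.56 log units; beyond the scatter). Compound 4 is therefore estimated at 5000 nM, between 1500 nM and 15000 nM.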

Compound 4, half-maximal cytotoxic concentration: 10000 nM
Compound 4: the middle estimate sits 2.0-fold (0.30 log units) below what was measured; measured number inside the range.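

In this assay chloro in place of hydrogen on an aromatic carbon gives a 1.8-fold lower number from compound 3 to compound 4 (0.26 log units; within the scatter) and so, on the core of compound 3, cannot be told apart from the scatter. The change therefore does not carry over at one size from the core of compound 1 to the core of compound 3: the same change on two cores in this assay, an at least 5.5-fold lower number (0.74 log units; beyond the scatter) from compound 1 to compound 2 and a 1.8-fold lower number (0.26 log units; within the scatter) from compound 3 to compound 4, at least 3.0-fold (0.48 log units) apart, beyond the scatter of two such steps
Compound 1 sits at a limit of the assay and not a number, so the full size of the earlier step stays unknown, and two cores give no rule for the change and no reason why the steps part: the limit of > 100000 nM in this assay, at which 1 of the 4 values shown sits.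

Left open is how fluoro, methyl or an amine in place of the chloro would stand in this assay on either core. Also open, as far as these compounds go, is whether the gap between the two steps would hold on a third core.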